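A few compounds are considered here, and "the series" means these few. Any claim that something is new, unique, unknown or untested is made for them only; others in the source may bear on it.

Measured in an ADME assay on BJ cells (Homo sapiens) for cytotoxicity, with a stated time of 72 h; on this read-out lower numbers stand for an effect already at smaller amounts and higher numbers for an effect only at larger amounts of compound:
- Compound 1 `Cc1nn(-c2ccccc2)c2nc(-c3ccc(C(F)(F)F)cc3)c(C#N)c(-c3ccccc3O)c12`: 22900 nM
- Compound 2 `Cc1nn(-c2ccccc2)c2nc(-c3ccc(F)cc3)c(C#N)c(-c3ccccc3O)c12`: > 20000 nM, a limit of the assay
- Compound 3 `Cc1nn(-c2ccccc2)c2nc(-c3ccc(I)cc3)c(C#N)c(-c3ccccc3O)c12`: 19000 nM

Within the data shown here, compound 3 stands level, within the scatter, with the only other exact number in the set: a 1.2-fold lower number from compound 1 to compound 3 (0.08 log units; within the scatter). Compound 4 `Cc1nn(-c2ccccc2)c2nc(-c3ccc(C#N)cc3)c(C#N)c(-c3ccccc3O)c12` carries cyano in place of iodo on an aromatic carbon, para to a large group: cyano in place of iodo on an aromatic carbon. Two measured swaps at this place bear on it. One is a 1.2-fold lower number from compound 1 to compound 3 (0.08 log units; within the scatter). The other is an at least 1.0-fold lower number from compound 2 to compound 3 (0.02 log units; that floor lies within the scatter). The swap a step that the limit leaves unreadable from compound 1 to compound 2 adds no size. No step beyond the scatter is therefore expected in this assay. The expected change is a 1.1-fold higher number from compound 3 to compound 4 (0.02 log units; within the scatter). Compound 4 is estimated at 20000 nM, with a range of 11000 nM to 35000 nM.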

Compound 4, half-maximal effective concentration in the BJ assay: > 20000 nM
Compound 4 was reported as a limit; the forecaster's own chance of this, stated with the estimate: 35%; the middle value sits exactly at the limit.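

In the BJ assay, compound 4 is reported only as a limit, > 20000 nM, and so cyano joins fluoro as a second group at this place without an exact number: the limit of > 20000 nM in the BJ assay, at which 2 of the 4 values shown sit. In the BJ assay, compound 3 gives 19000 nM, cyano in place of iodo gives an at least 1.0-fold higher number from compound 3 to compound 4 (0.02 log units; that floor lies within the scatter), and the steps from compound 1 and from compound 2 to compound 4 cannot be read. In a physicochemical assay for solubility, read by spectrophotometry, in phosphate buffer, with a stated time of 18 h, at pH 7.4 (a lower number here means a less soluble compound, a higher number a more soluble compound), compound 3 gives 1500 nM and compound 4 gives 1700 nM, and the same swap gives a 1.1-fold higher number from compound 3 to compound 4 (0.05 log units; within the scatter).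

Going by these compounds, how far compound 2 and compound 4 lie past their limits stays open. So does what an amine or a carboxylic acid at this place would do in the BJ assay.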